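The source may hold more compounds than are shown below. What is called first, only, known or untested is meant among the compounds shown, and "the series" means these compounds.

Three compounds built on the shared core, the structure of compound 1 being `N#CC1=C(N)Oc2c(c3nc4ccccc4nc3c3ccccc23)C12C(=O)N(Cc1cnnn1-c1ccccc1Br)c1ccccc12`, have been tested in a functional assay on HCT-116 cells (Homo sapiens) for antiproliferative activity, read by MTT assay, with a stated time of 48 h; a lower number here means a stronger inhibitor, a higher number a weaker inhibitor. In this assay compound 1 gives > 50000 nM, which is a limit of the assay rather than a number. Compound 2, `N#CC1=C(N)Oc2c(c3nc4ccccc4nc3c3ccccc23)C12C(=O)N(Cc1cnnn1-c1cccc(Br)c1)c1ccccc12`, carries a 3-bromophenyl in place of the 2-bromophenyl on an aromatic nitrogen, and in this assay compound 2 also gives > 50000 nM, again a limit. The step that the two limits leave unreadable from compound 1 to compound 2 therefore cannot be read. Compound 3, `N#CC1=C(N)Oc2c(N)cc3nc4ccccc4nc3c2C12C(=O)N(Cc1cnnn1-c1ccc(F)cc1)c1ccccc12`, gives > 50000 nM in this assay, once more a limit, so compound 3 stands where the other two stand, at the limit of > 50000 nM in this assay, at which 3 of the 3 values shown sit.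

Compound 4, `Cc1ccc(C)c(-n2nncc2CN2C(=O)C3(C(C#N)=C(N)Oc4c(N)cc5nc6ccccc6nc5c43)c3ccccc32)c1`, differs from compound 3 in one place: 2,5-dimethylphenyl in place of 4-fluorophenyl on an aromatic nitrogen. Within the data shown here, the only measured step, the one from compound 1 to compound 2, is unreadable because of the limit of > 50000 nM in this assay, at which 3 of the 3 values shown sit, so no measured step gives a size for an exchange of this kind. With all three values sitting at the limit, the expectation for compound 4 is that it too will most likely sit at or near that limit, and the step that the limit leaves unreadable from compound 3 to compound 4 is estimated to be no larger than the scatter. The estimate for compound 4 in this assay is therefore 60000 nM, within a range from 15000 nM to 200000 nM.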

Compound 4, half-maximal inhibitory concentration: > 50000 nM
Compound 4 was reported as a limit; the forecaster's own chance of this, stated with the estimate: 80%; the middle value lies beyond the limit too.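

No size can be read for the exchange of 4-fluorophenyl for 2,5-dimethylphenyl between compound 3 and compound 4, because both compounds stop at a limit of the assay rather than at a number: the limit of > 50000 nM in this assay, at which 4 of the 4 values shown sit. The compounds shown leave open whether any group at this place, or any change to the shared core, gives a measurable value in this assay at all.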